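The source may hold more compounds than are shown below. What is called first, only, known or untested is meant among the compounds shown, and "the series" means these compounds.

Within the data shown here, in a functional assay on MDA-MB-231 cells (Homo sapiens) for cytotoxicity, read by MTT assay, with a stated time of 48 h (a higher number here means a weaker inhibitor, a lower number a stronger inhibitor), compound 1 `COc1cc(/C=C/c2ccc(OCCCC(=O)NO)cc2)cc(OC)c1` gives 3890 nM and compound 2 `COc1cc(/C=C/c2ccc(OCCCCCCCC(=O)NO)cc2)cc(OC)c1` gives 5050 nM, so compound 2 stands within the scatter of the only other measured compound. Among the measured compounds shown here, the single measured step, a 1.3-fold higher number from compound 1 to compound 2 (0.11 log units; within the scatter), also stays within the scatter. Compound 3 `COc1cc(/C=C/c2ccc(OCCc3cn(CC(=O)NO)nn3)cc2)cc(OC)c1` differs from compound 2 as follows: 1-((hydroxycarbamoyl)methyl)-1H-1,2,3-triazol-4-yl in place of 5-(hydroxycarbamoyl)pentyl on a saturated chain carbon, two bonds along the chain from an oxygen on an aromatic ring. For the measured compounds named here, no measured step covers a five-membered aromatic ring in the chain, so that step gives only weak guidance and the range stays wide. No shift beyond the scatter is expected, and the estimated step is a 1.2-fold higher number from compound 2 to compound 3 (0.07 log units; within the scatter). For compound 3 the estimate is 6000 nM, with an expected range of 2000 nM to 20000 nM.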

Compound 3, half-maximal inhibitory concentration: 6520 nM
Beside the measured number, compound 3's estimate is 1.1-fold (0.04 log units) below it; measured number inside the range.
By their numbers in this assay, from the lowest: compounds 1, 2 and 3 (each within the scatter of the next).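

The triazole-containing chain changes little in this assay: 1-((hydroxycarbamoyl)methyl)-1H-1,2,3-triazol-4-yl in place of 5-(hydroxycarbamoyl)pentyl gives a 1.3-fold higher number from compound 2 to compound 3 (0.11 log units; within the scatter), and in place of (hydroxycarbamoyl)methyl it gives a 1.7-fold higher number from compound 1 to compound 3 (0.22 log units; within the scatter). Both steps lie within the scatter, so this position accepts a five-membered aromatic ring with 3 hetero atoms in the chain without a readable shift. No supporting data offer an explanation for this result. Still open, from the compounds shown here alone, is whether a longer chain beyond the ring, or a carboxylic acid or an amine in place of the hydroxycarbamoyl end, would shift the number beyond the scatter.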